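From 4-fluorophenyl to 4-ethylphenyl in the series

A few compounds are considered here, and "the series" means these few. Any claim that something is new, unique, unknown or untested is made for them only; others in the source may bear on it.

Compound 1 (`COC1=C(C)C(=O)/C(=C(O)/C=C/c2cccc(OC)c2)C(=O)C1(C)C`), compound 2 (`COC1=C(C)C(=O)/C(=C(O)/C=C/c2ccc(O)cc2)C(=O)C1(C)C`) and compound 3 (`COC1=C(C)C(=O)/C(=C(O)/C=C/c2ccc(F)cc2)C(=O)C1(C)C`) share one core and differ in the substituted phenyl group on the chain. In a functional assay on HUVEC cells (Homo sapiens) (a lower number here means that less compound is needed, a higher number that more compound is needed for the effect), compound 1 gives < 4 ug/mL as a limit, not a number. Compound 2 gives < 4 ug/mL, again a limit. Compound 3 gives < 4 ug/mL, also a limit, so it stands without a number of its own. Going by the values given here, the series so far reads as follows: the limit of < 4 ug/mL in this assay, at which 3 of the 3 values shown sit.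

Compound 4 (`CCc1ccc(/C=C/C(O)=C2/C(=O)C(C)=C(OC)C(C)(C)C2=O)cc1`) carries ethyl in place of fluoro on an aromatic carbon, para to a large group (ethyl in place of fluoro on an aromatic carbon). The closest measured step (a step that the two limits leave unreadable from compound 2 to compound 3) also exchanges a group on an aromatic carbon. The two others (a step that the two limits leave unreadable from compound 1 to compound 2) and (a step that the two limits leave unreadable from compound 1 to compound 3) exchange the whole substituted phenyl group. None of these steps has a readable size, so they offer neither a size nor a direction for the new change. All three phenyl variants end at the same limit in this assay, and no step beyond the scatter is expected. The estimated step (a step that the limit leaves unreadable from compound 3 to compound 4) carries no firm direction. Compound 4 is expected at 2 ug/mL (estimated range from 0.7 ug/mL to 5 ug/mL).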

Compound 4, concentration for half-maximal effect: < 4 ug/mL
Compound 4: no number, only a limit; the forecaster's own chance of this, stated with the estimate: 70%; the middle value lies beyond the limit too.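

In this assay compound 4 gives < 4 ug/mL, which is a limit. No step between compound 4 and compound 1, compound 2 or compound 3 can be read, and the series rests on one limit: the limit of < 4 ug/mL in this assay, at which 4 of the 4 values shown sit.

The compounds shown leave open whether, and by how much, the four phenyl variants differ in this read-out.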